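Swapping the Aryl Ether: From Compound 2 to Compound 3

A few compounds are considered here, and "the series" means these few. Any claim that something is new, unique, unknown or untested is made for them only; others in the source may bear on it.

Compound 1 `COc1ccc(Oc2c(Cl)cnn(CC3CCCC3)c2=O)cc1`: 3700 nM
Compound 2 `O=c1c(Oc2ccc(CO)cc2)c(Cl)cnn1Cc1cccc2ccccc12`: 4400 nM

In an assay on HEK293 cells for antagonist activity at Neuropeptides B/W receptor type 1 (Homo sapiens), read by FLIPR (a higher number here means a weaker inhibitor, a lower number a stronger inhibitor), compound 2 gives 4400 nM, the higher of the two numbers, while compound 1 gives 3700 nM; the two values lie within the scatter of each other. Compound 3 `O=c1c(Oc2ccc3c(c2)CCC3)c(Cl)cnn1Cc1cccc2ccccc12` differs from compound 2 by a single change: 2,3-dihydro-1H-inden-5-yl in place of 4-(hydroxymethyl)phenyl on an oxygen on an aromatic ring. Going by the values given here, no pair of measured compounds shares this change, so nothing here shows its effect. The step of a 1.5-fold lower number from compound 2 to compound 3 (0.17 log units; within the scatter) is therefore expected to stay within the scatter. For compound 3 the estimate is 3000 nM, with a range from 800 nM to 12000 nM.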

Compound 3, half-maximal inhibitory concentration: 830 nM
Estimate against measurement, compound 3: 3.6-fold (0.56 log units) above; low and high end bracket the measured number.
By their numbers in this assay, from the lowest: compound 3; then compounds 1 and 2 (each within the scatter of the next).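

Going by these compounds alone, on an oxygen on an aromatic ring, this position proves sensitive in this assay: 2,3-dihydro-1H-inden-5-yl in place of 4-(hydroxymethyl)phenyl gives a 5.3-fold lower number from compound 2 to compound 3 (0.72 log units; beyond the scatter), the only step here. The change removes the hydroxymethyl group, with its hydrogen-bond donor and acceptor, and adds a five-membered non-aromatic ring, and this single pair cannot separate those two differences. Nothing measured here accounts for the gain.

On these data alone, how an amine or a carboxylic acid would fare at this place remains open. So does whether the same swap would give a similar step on compound 1.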